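Working notes: isomeric alkyl change from compound 2

This account rests on a few compounds, and the source may have more. Where it says the series, first, only, none or still open, it means among the compounds named here.

In a functional assay on the whole organism with Mus musculus as the target, with a stated time of 2 h (on this read-out lower numbers stand for an effect already at smaller amounts and higher numbers for an effect only at larger amounts of compound), compound 2 (`CCC(C)C(C)OC(=O)Nc1ccc(S(N)(=O)=O)cc1`) gives 53 mg/kg and compound 1 (`CCCC(COC(=O)Nc1ccc(S(N)(=O)=O)cc1)C(C)CC`) gives 74 mg/kg with the two numbers within the scatter of each other. Compound 3 (`CCC(C)CCOC(=O)Nc1ccc(S(N)(=O)=O)cc1`) is not yet measured. It carries 3-methylpentyl in place of 1,2-dimethylbutyl on an oxygen next to a carbonyl group. Among the compounds with values here, no step between measured compounds differing in one place is available, so the expectation in this assay is of no shift beyond the scatter. The expected size of the change is a 1.1-fold higher number from compound 2 to compound 3 (0.05 log units; within the scatter) and this estimate stays within the scatter. For compound 3 the estimated value is 60 mg/kg with an expected range from 30 mg/kg to 115 mg/kg on this read-out.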

Compound 3, dose for half-maximal effect: 80 mg/kg
The estimate for compound 3 lay 1.3-fold (0.12 log units) below the measured number; measured number inside the range.
By their numbers in this assay, from the lowest: compounds 2, 1 and 3 (each within the scatter of the next).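

Swapping 1,2-dimethylbutyl for 3-methylpentyl on an oxygen next to a carbonyl group gives a step in this assay (a 1.5-fold higher number from compound 2 to compound 3 (0.18 log units; within the scatter)) that does not separate the two isomers. Hydrogen in place of propyl on a saturated chain carbon bound to two saturated chain carbons also leaves the two compounds unseparated (a 1.1-fold higher number from compound 1 to compound 3 (0.03 log units; within the scatter)). Nothing measured accounts for these steps staying within the scatter.

As far as these compounds go, whether a longer chain or an amine in place of these alkyl groups would shift the number beyond the scatter stays open.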